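This account rests on a few compounds, and the source may have more. Where it says the series, first, only, none or still open, it means among the compounds named here.

Compound 1 `Cc1c(O)ccc2c1[C@H](Cn1cc(-c3ccc(F)cc3)nn1)[C@@]13CC(=O)[C@@](C)(CC[C@@H]21)C3` and compound 3 `Cc1ccc(S(=O)(=O)Oc2ccc3c(c2C)[C@H](Cn2cc(-c4ccc(F)cc4)nn2)[C@@]24CC(=O)[C@@](C)(CC[C@@H]32)C4)cc1` share a core and differ in one place ((4-methylphenyl)sulfonyl in place of hydrogen on an oxygen on an aromatic ring). In a functional assay on SMMC-7721 cells (Homo sapiens) for cytotoxicity, read by MTT assay, with a stated time of 4 days (a higher number here means a weaker inhibitor, a lower number a stronger inhibitor), compound 1 gives > 20000 nM, which is a limit of the assay rather than a number. In this assay compound 3 likewise gives > 20000 nM, again a limit. The step that the two limits leave unreadable from compound 1 to compound 3 therefore cannot be read, because both values sit at the limit of > 20000 nM in this assay, at which 2 of the 3 values shown sit. Compound 2 `C=C1C(=O)[C@]23C[C@@]1(O)CC[C@H]2c1ccc(O)c(C)c1[C@@H]3Cn1cc(-c2ccc(OC)cc2)nn1` is built on a different core; how it differs from compound 1 is not broken down here. In this assay, for the measured compounds named here, compound 2 gives 860 nM, the only number among the three. Compound 4 `C=C1C(=O)[C@]23C[C@@]1(O)CC[C@H]2c1ccc(OS(=O)(=O)c2ccc(C)cc2)c(C)c1[C@@H]3Cn1cc(-c2ccc(OC)cc2)nn1` carries the same change on the core of compound 2 ((4-methylphenyl)sulfonyl in place of hydrogen on an oxygen on an aromatic ring). Since the measured step gives no size, the expectation for compound 4 rests only on the value of compound 2 860 nM, with a moderate loss allowed; the step of a 2.3-fold higher number from compound 2 to compound 4 (0.37 log units; beyond the scatter) is estimated. Compound 4 is expected to give about 2000 nM, between 500 nM and 10000 nM.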

Compound 4, half-maximal inhibitory concentration: 1720 nM
For compound 4 the middle estimate is 1.2-fold (0.07 log units) above the measured one, and the stated range covers the measured number.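

In this assay, replacing hydroxy with ((4-methylphenyl)sulfonyl)oxy gives a 2.0-fold higher number from compound 2 to compound 4 (0.30 log units; within the scatter), so on this core the two values cannot be told apart. On the core of compound 1, the step to compound 3 cannot be read, since both values are limits of the assay and not numbers: the limit of > 20000 nM in this assay, at which 2 of the 4 values shown sit. The series therefore offers one readable instance of this change, and it does not show that the change behaves alike on both cores.

On these data alone, whether a smaller group on the same oxygen, such as acetyl or methanesulfonyl, would read the same stays open. As far as these compounds go, compound 1 and compound 2 differ in more than one place, so what separates them also stays open.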